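This account rests on a few compounds, and the source may have more. Where it says the series, first, only, none or still open, it means among the compounds named here.

Measured in an assay on HEK293 cells for inhibition of Indoleamine 2,3-dioxygenase 1 (Homo sapiens), tested at 10 uM; a lower number here means less inhibition, a higher number more inhibition at the concentration tested (going by the name of the read-out):
- compound 1 `CCC(=O)N1CCc2cc(CNC(=O)c3cccs3)ccc21`: 89%
- compound 2 `CCC(=O)N1CCc2cc(CNC(=O)c3ccc(F)cc3)ccc21`: 96%
- compound 3 `CCC(=O)N1CCc2cc(CNC(=O)c3ccnn3C)ccc21`: 14%

Compound 1 stands near the top of these three numbers. The step of a number 7 percentage points higher from compound 1 to compound 2 (within the scatter) lies within the scatter, so compound 1 and compound 2 cannot be separated on these data. Within the data shown here, the step of a number 75 percentage points lower from compound 1 to compound 3 (beyond the scatter) is large, as is a number 82 percentage points lower from compound 2 to compound 3 (beyond the scatter); in this set, the one change that moves the read-out is the swap of the group on the carbonyl carbon of the amide for 1-methyl-1H-pyrazol-5-yl.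

Compound 4 `CC(C)CC(=O)N1CCc2cc(CNC(=O)c3cccs3)ccc21` keeps thiophen-2-yl on that carbonyl and differs from compound 1 elsewhere: isopropyl in place of methyl on a saturated chain carbon bound to a carbonyl carbon. Among the measured compounds shown here, none of the measured steps touch this saturated chain carbon; all three alter the amide substituent and leave the propanoyl unchanged. For the measured compounds named here, there is therefore no measured step that bears directly on this change, and the expectation is a step no larger than the scatter, in no settled direction, a number 4 percentage points lower from compound 1 to compound 4 (within the scatter).

For compound 4 the estimate in this assay is 85%, with a range from 62% to 97%.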

Compound 4, a percentage reported as inhibition, at one concentration (the size of the read-out at that concentration, not a potency): 100%
Estimate against measurement, compound 4: 15 percentage points below, and the stated range ends below it.
By their numbers in this assay, from the lowest: compound 3; then compounds 1, 2 and 4 (each within the scatter of the next, the first and the last beyond it).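

Among these compounds, this is the first measured change at the saturated chain carbon bound to a carbonyl carbon: in this assay, isopropyl in place of methyl gives a number 11 percentage points higher from compound 1 to compound 4 (beyond the scatter) and, with thiophen-2-yl kept on the amide carbonyl, the read-out does not fall. With compound 4 at 100% on a percentage read-out taken at one concentration, any further gain at this place could not show in this assay. Nothing at hand offers an explanation for this step.

From the compounds shown here alone, whether a longer chain, an amine or a carboxylic acid at this place would hold the read-out remains open. So does whether isopropyl in place of methyl would raise the low number of compound 3 14% with its 1-methyl-1H-pyrazol-5-yl group kept.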